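This account rests on a few compounds, and the source may have more. Where it says the series, first, only, none or still open, it means among the compounds named here.

Compound 2 `O=C(NCc1ccccc1)c1cccc(/C=C2\CC(=O)N(c3ccccc3)C2=O)c1` is a cytotoxicity probe, tested in an ADME assay on NCM460 cells (Homo sapiens) for cytotoxicity, read by MTT assay, with a stated time of 72 h; a higher number here means a weaker inhibitor, a lower number a stronger inhibitor. In this assay compound 2 gives > 100000 nM, which is a limit of the assay rather than a number. Its nearest measured relative, compound 1 `COc1ccc(NC(=O)c2cccc(/C=C3\CC(=O)N(c4ccccc4)C3=O)c2)c(C)c1`, carries a different group on the amide nitrogen. In this assay compound 1 gives > 100000 nM, again a limit. The step that the two limits leave unreadable from compound 1 to compound 2 therefore cannot be read in size or direction; both values sit at the limit of > 100000 nM in this assay, at which 2 of the 2 values shown sit.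

Compound 3 `O=C(c1cccc(/C=C2\CC(=O)N(c3ccccc3)C2=O)c1)N1CCCC1` is the next variation on the same carbonyl carbon: pyrrolidin-1-yl in place of benzylamino on a carbonyl carbon. Among the measured compounds shown here, no measured step mirrors this change, and the only step that shares its neighbourhood is unreadable, so the expectation rests on the two limits alone. Compound 3 is expected to remain weak in this assay, with a step that the limit leaves unreadable from compound 2 to compound 3 that most likely stays at the limit. The estimate for compound 3 in this assay is 150000 nM, within 60000 nM to 400000 nM.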

Compound 3, half-maximal inhibitory concentration: > 100000 nM
Compound 3 was reported as a limit (the forecaster's own chance of this, stated with the estimate: 80%); the middle value does not contradict the limit.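

Compound 3 also ends at a limit of the assay rather than a number, so its steps from compound 1 and compound 2 cannot be read in size or direction: the limit of > 100000 nM in this assay, at which 3 of the 3 values shown sit.

The compounds shown leave open how far past this limit each one lies, and whether any other group on the carbonyl carbon would give a measurable value.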